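A few compounds are considered here, and "the series" means these few. Any claim that something is new, unique, unknown or untested is made for them only; others in the source may bear on it.

Compound 1 `C=C1C(=O)[C@]23C[C@@]1(O)CC[C@H]2c1ccc(O)c(C)c1[C@@H]3Cn1cc(-c2ccccn2)nn1` and compound 3 `C=C1C(=O)[C@]23C[C@@]1(O)CC[C@H]2c1ccc(O)c(C)c1[C@@H]3Cn1cc(-c2ccc(C(F)(F)F)cc2)nn1` share one core, while compound 2 `Cc1c(O)ccc2c1[C@H](Cn1cc(-c3ccccn3)nn1)[C@@]13CC(=O)[C@@](C)(CC[C@@H]21)C3` and compound 4 `Cc1c(O)ccc2c1[C@H](Cn1cc(-c3ccc(C(F)(F)F)cc3)nn1)[C@@]13CC(=O)[C@@](C)(CC[C@@H]21)C3` share another; the difference between the two cores is not broken down here. In a functional assay on SMMC-7721 cells (Homo sapiens) for cytotoxicity, read by MTT assay, with a stated time of 4 days (on this read-out lower numbers stand for stronger inhibition and higher numbers for weaker inhibition), compound 1 gives 1270 nM. Compound 3 differs from compound 1 by 4-(trifluoromethyl)phenyl in place of pyridin-2-yl on an aromatic carbon. In this assay compound 3 gives 1440 nM. The change made a 1.1-fold higher number from compound 1 to compound 3 (0.05 log units; within the scatter), so the two values stand together. For compound 2, this assay reports only a limit, > 20000 nM, which is the upper bound of what this measurement can report (the limit of > 20000 nM in this assay, at which 1 of the 3 values shown sits). Compound 4 carries the same change relative to compound 2 that compound 3 carries relative to compound 1: 4-(trifluoromethyl)phenyl in place of pyridin-2-yl on an aromatic carbon. Because the same change gave a 1.1-fold higher number from compound 1 to compound 3 (0.05 log units; within the scatter) from compound 1 to compound 3, compound 4 is expected to stay where compound 2 stood, with an estimated step that the limit leaves unreadable from compound 2 to compound 4. Compound 4 is therefore expected to give about 25000 nM in this assay, most plausibly between 10000 nM and 60000 nM, and most likely to be reported again only as a limit.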

Compound 4, half-maximal inhibitory concentration: > 20000 nM
Compound 4 ended at the assay's limit (the forecaster's own chance of this, stated with the estimate: 75%); the middle value lies beyond the limit too.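

In this assay, within the data shown here, compound 4 gives > 20000 nM which is only a limit, as is the result for compound 2, so no step between compound 2 and compound 4 can be read: the limit of > 20000 nM in this assay, at which 2 of the 4 values shown sit. The compounds shown leave open how far beyond that limit compound 2 and compound 4 lie, and whether the change has any effect on their core.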